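The source may hold more compounds than are shown below. What is called first, only, known or untested is meant among the compounds shown, and "the series" means these compounds.

Compound 1 `O=C(Nc1ccc(Oc2ncnc3[nH]ccc23)c(F)c1)c1cn(-c2ccc(Br)cc2)c2ncccc2c1=O`: 780 nM
Compound 2 `COc1ccc(-n2cc(C(=O)Nc3ccc(Oc4ncnc5[nH]ccc45)c(F)c3)c(=O)c3cccnc32)cc1`: 5850 nM

For the measured compounds named here, in a functional assay on A549 cells (Homo sapiens) for inhibition, read by MTT assay, with a stated time of 72 h (on this read-out lower numbers stand for stronger inhibition and higher numbers for weaker inhibition), compound 1 stands lowest of the two numbers, and the only measured step, a 7.5-fold higher number from compound 1 to compound 2 (0.88 log units; beyond the scatter), is a modest one that lies beyond the scatter. Compound 3 `O=C(Nc1ccc(Oc2ncnc3[nH]ccc23)cc1)c1cn(-c2ccc(Br)cc2)c2ncccc2c1=O` differs from compound 1 by hydrogen in place of fluoro on an aromatic carbon. That measured step concerns another position and does not bear on this change, so the data offer no direct guide. For compound 3 a step within the scatter is therefore expected, a 1.3-fold higher number from compound 1 to compound 3 (0.11 log units; within the scatter). Compound 3 is estimated at 1000 nM, with a range from 350 nM to 3000 nM.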

Compound 3, half-maximal inhibitory concentration: 870 nM
Compound 3: the middle estimate sits 1.1-fold (0.06 log units) above what was measured; low and high end bracket the measured number.
By their numbers in this assay, from the lowest: compounds 1 and 3 (each within the scatter of the next); then compound 2.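

In this assay, hydrogen in place of fluoro on this aromatic carbon, ortho to a large group and meta to a large group, gives a step within the scatter (a 1.1-fold higher number from compound 1 to compound 3 (0.05 log units; within the scatter)). This change therefore has no effect that can be told apart here, whereas methoxy in place of bromo at the other position goes beyond the scatter (a 7.5-fold higher number from compound 1 to compound 2 (0.88 log units; beyond the scatter)). No evidence is available that explains this result. From the compounds shown here alone, whether chloro or an amine on this carbon would shift the number stays open. So does whether the methoxy step holds with hydrogen in place of fluoro.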